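One group exchanged on compound 1

The source may report more compounds than this note shows. Statements on the series, on what has been measured and on what is new or still open speak of the compounds shown alone.

Compound 1 `COc1ccc(NC(=O)NCCNS(=O)(=O)c2ccc(-c3ccccc3OCc3ccccc3)s2)cc1`: > 50000 nM (a limit)
Compound 2 `Cc1ccc(-c2ccsc2S(=O)(=O)NCCNC(=O)Nc2cc(C(F)(F)F)cc(C(F)(F)F)c2)c(Oc2ccc(O)c(O)c2)c1`: 3700 nM
Compound 3 `O=S(=O)(NCCNC(=S)Nc1cc(C(F)(F)F)cc(C(F)(F)F)c1)c1ccc(-c2ccccc2OCc2ccccc2)s1`: 2100 nM

All three compounds were tested in a functional assay on HL-60 cells (Homo sapiens) for inhibition, read by CCK-8 assay, with a stated time of 48 h; a higher number here means a weaker inhibitor, a lower number a stronger inhibitor. Compound 1 stands at the limit of > 50000 nM in this assay, at which 1 of the 3 values shown sits. That entry is a limit and not a number. Compound 2 gives 3700 nM and compound 3 gives 2100 nM, two values within the usual scatter of each other.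

Compound 4 `O=[N+]([O-])c1cccc(NC(=S)NCCNS(=O)(=O)c2ccc(-c3ccccc3OCc3ccccc3)s2)c1` departs from compound 1 in a single place, an amine nitrogen, where the (4-methoxyphenyl)carbamoyl group leaves: a group of 12 heavy atoms (7 carbon, 2 nitrogen, 2 oxygen, 1 sulfur; one six-membered aromatic ring of carbon only) in place of a group of 11 heavy atoms (8 carbon, 1 nitrogen, 2 oxygen; one six-membered aromatic ring of carbon only), on an amine nitrogen. Among the measured compounds shown here, no measured pair shows what such an exchange does. Even so, a step beyond the scatter is expected in this assay, towards a stronger inhibitor, and this expectation leans on compound 3 at 2100 nM. The expected change is an at least 8.3-fold lower number from compound 1 to compound 4 (0.92 log units; beyond the scatter). For compound 4 the estimated value is 6000 nM. The expected range for compound 4 runs from 2000 nM to 25000 nM.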

Compound 4, half-maximal inhibitory concentration: > 50000 nM
Compound 4: no number, only a limit; the forecaster's own chance of this, stated with the estimate: 15%; at least 8.3-fold (0.92 log units) between middle value and limit.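

No step can be read from compound 1 to compound 4, since the entries of both in this assay are limits and not numbers: the limit of > 50000 nM in this assay, at which 2 of the 4 values shown sit. The compounds shown leave open whether the exchange on the amine nitrogen changes inhibition at all, and by how much.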